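Chloro for Fluoro Carried onto a Second Core

The source may report more compounds than this note shows. Statements on the series, on what has been measured and on what is new or still open speak of the compounds shown alone.

Compound 1 `O=C(Nc1nnc(-c2ccc(F)cc2)s1)c1cc(Cl)ccc1O` and compound 2 `O=C(Nc1nnc(-c2ccc(Cl)cc2)s1)c1cc(Cl)ccc1O` share one core and differ in a single place. In a functional assay on B16-F10 cells (Mus musculus) for antiproliferative activity, read by MTT assay, with a stated time of 48 h (on this read-out higher numbers stand for weaker inhibition and lower numbers for stronger inhibition), compound 1 gives 680 nM, and compound 2 gives 310 nM. The change between them, (chloro in place of fluoro on an aromatic carbon), made a 2.2-fold lower number from compound 1 to compound 2 (0.34 log units; beyond the scatter). Compound 3 `O=C(Nc1nnc(-c2ccc(F)cc2)s1)c1ccccc1` rests on a different core, and the difference between the two cores is not broken down here. In this assay compound 3 gives 4750 nM, the highest of the three numbers, with compound 1 nearest and compound 2 furthest from it. Compound 4 `O=C(Nc1nnc(-c2ccc(Cl)cc2)s1)c1ccccc1` carries the same change onto the core of compound 3: chloro in place of fluoro on an aromatic carbon. The place is described in the same words for both pairs, so this counts as the same change, now made on a core that starts from a weaker number. Resting on a 2.2-fold lower number from compound 1 to compound 2 (0.34 log units; beyond the scatter), compound 4 is expected to show a 2.2-fold lower number from compound 3 to compound 4 (0.33 log units; beyond the scatter). On that basis compound 4 is estimated at 2200 nM, with a likely range from 1000 nM to 5000 nM.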

Compound 4, half-maximal inhibitory concentration: 4060 nM
Beside the measured number, compound 4's estimate is 1.8-fold (0.27 log units) below it; low and high end bracket the measured number.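

In this assay, among the compounds shown here, chloro in place of fluoro on the core of compound 3 gives a 1.2-fold lower number from compound 3 to compound 4 (0.07 log units; within the scatter), so on this core the change leaves no step that stands clear of the scatter, although on the core of compound 1 it did. Even so, the two steps cannot be told apart: the same change on two cores in this assay, a 2.2-fold lower number (0.34 log units; beyond the scatter) from compound 1 to compound 2 and a 1.2-fold lower number (0.07 log units; within the scatter) from compound 3 to compound 4, 1.9-fold (0.27 log units) apart, within the scatter of two such steps. This shows that the results on the two cores are compatible with a single modest effect, but it does not show that the effect is the same on both, or that it is really present on the core of compound 3, and one pair on each core is too little to establish a rule for the series.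

The compounds shown leave open how a bromo, a methyl or a methoxy group, or an amine, would compare with fluoro and chloro at this place on the phenyl ring. They also leave open which part of the difference between the two cores goes with the large gap in their numbers.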